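Swapping a thiophene alkyne for a chlorophenyl on a C-nucleoside

The source may hold more compounds than are shown below. What is called first, only, known or untested is meant among the compounds shown, and "the series" means these compounds.

Two analogues sharing one nucleoside core have been measured so far. Compound 1 `Nc1ncnn2c([C@@H]3O[C@H](CO)[C@@H](O)[C@H]3O)cc(C#Cc3cccs3)c12` carries a 2-(thiophen-2-yl)ethynyl group; in a functional assay on CAPAN-1 cells (Homo sapiens) for antiproliferative activity, with a stated time of 72 h (a higher number here means a weaker inhibitor, a lower number a stronger inhibitor), compound 1 gives 32000 nM. Compound 2 `Nc1ncnn2c([C@@H]3O[C@H](CO)[C@@H](O)[C@H]3O)cc(-c3ccc(F)cc3)c12` carries a 4-fluorophenyl group in the same place, and in this assay compound 2 gives 65600 nM. Among these two numbers compound 1 stands at the lowest, its only neighbour being compound 2, and the step of a 2.1-fold higher number from compound 1 to compound 2 (0.31 log units; beyond the scatter) is modest but beyond the scatter.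

Compound 3 `Nc1ncnn2c([C@@H]3O[C@H](CO)[C@@H](O)[C@H]3O)cc(-c3ccc(Cl)cc3)c12` is the next analogue. It differs from compound 1 as follows: 4-chlorophenyl in place of 2-(thiophen-2-yl)ethynyl on an aromatic carbon. The step from compound 1 to compound 2 bears directly on this change, since both replace the 2-(thiophen-2-yl)ethynyl group with a six-membered aromatic ring bearing a single halogen. On that basis a modest rise in the number, or none beyond the scatter, is expected for compound 3, in line with a 2.1-fold higher number from compound 1 to compound 2 (0.31 log units; beyond the scatter). The estimated step is a 1.6-fold higher number from compound 1 to compound 3 (0.19 log units; within the scatter). Compound 3 is therefore expected to give about 50000 nM in this assay, within a range of 20000 nM to 130000 nM.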

Compound 3, half-maximal inhibitory concentration: 56700 nM
The estimate for compound 3 lay 1.1-fold (0.05 log units) below the measured number; measured number inside the range.
By their numbers in this assay, from the lowest: compounds 1, 3 and 2 (each within the scatter of the next, the first and the last beyond it).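

In this assay the exchange of the 2-(thiophen-2-yl)ethynyl group for 4-chlorophenyl gives a 1.8-fold higher number from compound 1 to compound 3 (0.25 log units; within the scatter) and so, unlike the exchange for 4-fluorophenyl, does not separate from the group it replaces. The halogen on the phenyl ring makes no readable difference here, as chloro in place of fluoro gives a 1.2-fold lower number from compound 2 to compound 3 (0.06 log units; within the scatter) and leaves the two halogenated compounds indistinguishable in this read-out. At this aromatic carbon, two ring bonds from the ring nitrogen, the only separation beyond the scatter is therefore the modest one between compound 1 and compound 2, with compound 3 within the scatter of both, so these three compounds show no clear preference between the alkyne and the halophenyl groups.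

Still open, going by these compounds, is whether an amine or a carboxylic acid on the phenyl ring, or a longer saturated chain in place of the ring, would move the number well outside this narrow band. The data at hand give no independent measurement that could explain why these three compounds lie so close together.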